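Swapping cyanoguanidine for thiourea on the longer chain

The source may hold more compounds than are shown below. What is called first, only, known or untested is meant among the compounds shown, and "the series" means these compounds.

Compound 3 `N#CNC(=N)NCCCCn1nc(-c2ccccc2)ccc1=O` is the only one of the three measured compounds that gives a number in a functional assay on the whole organism (stomach) with Rattus norvegicus as the target; a lower number here means that less compound is needed, a higher number that more compound is needed for the effect: compound 3 gives 77.2 mg/kg. Compound 1 `C/N=C(/NC#N)NCCCn1nc(-c2ccccc2)ccc1=O` reaches only a limit of the assay, not a number; in this assay compound 1 gives > 100 mg/kg. Compound 2 `CC/N=C(\S)NCCCn1nc(-c2ccccc2)ccc1=O` likewise ends at a limit and not a number; in this assay compound 2 gives > 100 mg/kg. Compound 3 therefore stands at the one readable point, with both other values sitting at the limit of > 100 mg/kg in this assay, at which 2 of the 3 values shown sit.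

Compound 4 `C/N=C(\S)NCCCCn1nc(-c2ccccc2)ccc1=O` carries a group of 4 heavy atoms (2 carbon, 1 nitrogen, 1 sulfur; no ring) in place of a group of 5 heavy atoms (2 carbon, 3 nitrogen; no ring), on an amine nitrogen. The closest measured parallel is a step that the two limits leave unreadable from compound 1 to compound 2, so the same kind of exchange on the shorter chain gives no readable size. The step of an at least 1.2-fold lower number from compound 2 to compound 3 (0.11 log units; that floor lies within the scatter) combines the reverse exchange with a longer chain, and an at least 1.2-fold lower number from compound 1 to compound 3 (0.11 log units; that floor lies within the scatter) shows the chain change on its own. From these, the thiourea on the longer chain is expected to give either a number in the same region as compound 3 or, quite possibly, only a limit again. Compound 4 is expected to land near 110 mg/kg, with a range from 50 mg/kg to 250 mg/kg. The expected step is then a 1.4-fold higher number from compound 3 to compound 4 (0.15 log units; within the scatter).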

Compound 4, dose for half-maximal effect: 28.9 mg/kg
Beside the measured number, compound 4's estimate is 3.8-fold (0.58 log units) above it, and the stated range ends above it.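

On the longer chain, replacing the cyanoguanidine end group with the thiourea end group now has a readable size in this assay: a 2.7-fold lower number from compound 3 to compound 4 (0.43 log units; beyond the scatter). Going by these compounds alone, this exchange therefore changes the dose needed at this amine nitrogen by more than the usual scatter, which the earlier compounds could not show, as the step between their two limits cannot be read. The thiourea on the longer chain also separates from both shorter-chain compounds, with an at least 3.4-fold lower number from compound 2 to compound 4 (0.53 log units; beyond the scatter) and an at least 3.4-fold lower number from compound 1 to compound 4 (0.53 log units; beyond the scatter), but these sizes are only floors, as compound 1 and compound 2 each end at a limit of the assay and not at a number: the limit of > 100 mg/kg in this assay, at which 2 of the 4 values shown sit.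

In both of those comparisons the chain and the end group change together, so the compounds shown cannot say how much of either step belongs to the chain and how much to the group on the amine nitrogen. On these data alone, it also remains open whether a urea, with oxygen where the thiourea has sulfur, or a still longer chain would keep, lower or raise the dose needed.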